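The source may hold more compounds than are shown below. What is called first, only, known or untested is meant among the compounds shown, and "the series" means these compounds.

Measured compounds:
compound 1 `FC(F)(F)c1ccc(COc2cccc(Nc3ncnc4cc5c(cc34)OCCOCCOCCO5)c2)cc1`, 24900 nM
compound 2 `c1ccc(COc2ccc(Nc3ncnc4cc5c(cc34)OCCOCCO5)cc2)cc1`, 43900 nM
compound 3 `FC(F)(F)c1ccc(COc2ccc(Nc3ncnc4cc5c(cc34)OCCOCCO5)cc2)cc1`, > 100000 nM

In a functional assay on A549 cells (Homo sapiens) for antiproliferative activity, read by MTT assay, with a stated time of 72 h (a lower number here means a stronger inhibitor, a higher number a weaker inhibitor), compound 1 gives 24900 nM and compound 2 gives 43900 nM, two numbers that lie within the usual scatter of each other. For compound 3 the value > 100000 nM is a limit of this assay rather than a number (the limit of > 100000 nM in this assay, at which 1 of the 3 values shown sits). The change from compound 3 to compound 2 is hydrogen in place of trifluoromethyl on an aromatic carbon, and it made a step of an at least 2.2-fold lower number from compound 3 to compound 2 (0.35 log units; beyond the scatter). Compound 4 `c1ccc(COc2cccc(Nc3ncnc4cc5c(cc34)OCCOCCOCCO5)c2)cc1` is not yet measured; it arises from compound 1 by the same change, (hydrogen in place of trifluoromethyl on an aromatic carbon), while the difference between the cores of compound 1 and compound 3 is not broken down here. A step of a 2.1-fold lower number from compound 1 to compound 4 (0.32 log units; beyond the scatter) is expected, resting on the earlier step of an at least 2.2-fold lower number from compound 3 to compound 2 (0.35 log units; beyond the scatter). Compound 4 is therefore estimated at 12000 nM in this assay.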

Compound 4, half-maximal inhibitory concentration: > 100000 nM
Compound 4: only a limit was reported (the forecaster's own chance of this, stated with the estimate: 5%); middle value at least 8.3-fold (0.92 log units) away from the limit.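

In this assay, replacing trifluoromethyl with hydrogen made a step of an at least 4.0-fold higher number from compound 1 to compound 4 (0.60 log units; beyond the scatter), so the change did not carry from one core to the other, and its direction reversed: the same change on two cores in this assay, an at least 2.2-fold lower number (0.35 log units; beyond the scatter) from compound 3 to compound 2 and an at least 4.0-fold higher number (0.60 log units; beyond the scatter) from compound 1 to compound 4, at least 9.1-fold (0.96 log units) apart, beyond the scatter of two such steps

Both steps rest on a limit of the assay, so their full sizes remain unknown: the limit of > 100000 nM in this assay, at which 2 of the 4 values shown sit.

The data do not show which part of the difference between the core of compound 1 and that of compound 3 goes with this reversal, nor why it occurs.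

On these data alone, whether chlorine, methoxy or nitrile in place of trifluoromethyl would keep the number near that of compound 1 remains open. So does how either core would respond to such groups.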